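From Compound 1 to Compound 4 in a Cell Viability Screen

A few compounds are considered here, and "the series" means these few. Any claim that something is new, unique, unknown or untested is made for them only; others in the source may bear on it.

Compound 1 `COC(=O)c1cc(C2=C(c3cc(OC)c(OC)c(OC)c3)C(=O)CC2O[SiH2]C(C)(C)C)ccc1OC` was examined in an ADME assay on ECV-304 cells (Homo sapiens) for cytotoxicity, read by MTT assay, with a stated time of 72 h; on this read-out higher numbers stand for weaker inhibition and lower numbers for stronger inhibition. In that assay compound 1 gave only the limit > 100 ug/mL, a bound rather than a number. Compound 2 `COc1ccc(C2=C(c3cc(OC)c(OC)c(OC)c3)C(=O)C(OC(C)=O)C2)cc1OC(C)C` likewise gave the limit > 100 ug/mL in this assay. For compound 3 `COc1ccc(C2=C(c3cc(OC)c(OC)c(OC)c3)C(=O)CC2OC(C)=O)cc1NC=O` the entry reads "not determined" (no result reported), so no number is available. Within the data shown here, compound 1 therefore stands with the two limit values of the set, (the limit of > 100 ug/mL in this assay, at which 2 of the 3 values shown sit), and no measured step between compounds exists to set a scale. Compound 4 `COc1cc(C2=C(c3ccccc3)C(O[SiH2]C(C)(C)C)CC2=O)cc(OC)c1OC` differs from compound 1 by phenyl in place of 4-methoxy-3-(methoxycarbonyl)phenyl on a double-bonded ring carbon. Because compound 1 gives > 100 ug/mL, compound 4 is expected to show 120 ug/mL, within 40 ug/mL to 300 ug/mL. The expected step that the limit leaves unreadable from compound 1 to compound 4 in this assay is no larger than the scatter.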

Compound 4, half-maximal inhibitory concentration: > 100 ug/mL
Compound 4: a limit, no number; the forecaster's own chance of this, stated with the estimate: 70%; the middle value is on the limit's open side.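

Among these compounds, compound 1 and compound 4 each carry only a limit in this assay, and no step between them can be read. The compounds shown leave open whether phenyl in place of 4-methoxy-3-(methoxycarbonyl)phenyl alters the read-out at all.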